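The source may hold more compounds than are shown below. What is called first, only, known or untested is meant among the compounds shown, and "the series" means these compounds.

Working notes on the series. Three compounds sharing one core have results in an in vitro assay on cells for inhibition of Amine oxidase [flavin-containing] A (Homo sapiens), read by Amplex Red, with a stated time of 15 min, tested at 100 uM; a higher number here means more inhibition at the concentration tested (going by the name of the read-out), a lower number less inhibition. Compound 1 `Cc1ccc(C2=NN(C(N)=S)CC2)cc1` gives "not active" (no number reported). Compound 2 `CC1CN(C(N)=S)N=C1c1ccc(F)cc1` gives 40%. Compound 3 `Cc1ccc(C2=NN(C(N)=S)CC2C)cc1` gives "not active" (no number reported), so no single number stands for it, and compound 1 is a second entry of the set without a single number. Going by the values given here, no step between two measured compounds is available, so nothing is known about how large a single change on this core moves the read-out.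

Compound 4 `CC1CN(C(N)=S)N=C1c1ccc(Cl)cc1` is not yet measured. It differs from compound 3 by chloro in place of methyl on an aromatic carbon.

Among the compounds with values here, without a comparable step, the direction and size of the change from compound 3 to compound 4 in this assay cannot be read off; the only guide is compound 2, which carries fluoro in the place where compound 4 carries chloro. In this assay compound 2 gives 40%. A reading in the same region as compound 2 is therefore expected, with wide uncertainty either way and a real chance that no number is reported. For compound 4 in this assay an inhibition of about 40% is estimated, in the range 15% to 65%.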

Compound 4, a percentage reported as inhibition, at one concentration (the size of the read-out at that concentration, not a potency): 40%
The estimate for compound 4 equals the measured number at the digits printed; low and high end bracket the measured number.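

In this assay, going by these compounds alone, the exchange of fluoro for chloro on the aromatic carbon gives no change at the digits printed from compound 2 to compound 4 (within the scatter) and is the first comparison on the shared core in which both compounds carry a number, so at this position the two halogens cannot be told apart. The exchange of methyl for chloro at the same aromatic carbon links compound 3 ("not active" (no number reported)) to compound 4 (40%), so a number is reported with chloro where none is reported with methyl, although that change cannot be read as a step of defined size. Nothing at hand gives a reason for these readings.

From the compounds shown here alone, whether an amine, a carboxylic acid or a longer chain at this aromatic carbon would keep a reading like that of compound 4 remains open. Also open, going by these compounds, is whether bromo would match fluoro and chloro here.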